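Swapping the Anilino Substituent: Chlorine Out, Methyl In

The source may hold more compounds than are shown below. What is called first, only, known or untested is meant among the compounds shown, and "the series" means these compounds.

Of the compounds shown here, three built on one shared core have been tested in a functional assay on MCF7 cells (Homo sapiens) for inhibition, read by MTT assay, with a stated time of 72 h; a lower number here means a stronger inhibitor, a higher number a weaker inhibitor. Compound 2, `N#Cc1c(Nc2cccc(Cl)c2)nc(SCc2cn(Cc3ccccc3Cl)nn2)nc1-c1ccccc1`, gives 12000 nM in this assay, and it is the only one of the three to yield a number rather than a limit. Compound 1, `C#CCSc1nc(Nc2cccc(Cl)c2)c(C#N)c(-c2ccccc2)n1`, gives > 128000 nM, which is a limit of the assay and not a number: the limit of > 128000 nM in this assay, at which 1 of the 3 values shown sits. Compound 3, `N#Cc1c(Nc2ccccc2F)nc(SCc2cn(Cc3ccc(Cl)cc3)nn2)nc1-c1ccccc1`, gives > 64000 nM, again a limit of the assay and not a number: the limit of > 64000 nM in this assay, at which 1 of the 3 values shown sits. Going by the values given here, no two of the measured compounds differ in a single place, so no measured step between them can be read off.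

Compound 4, `Cc1ccc(Nc2nc(SCc3cn(Cc4ccccc4Cl)nn3)nc(-c3ccccc3)c2C#N)cc1`, has yet to be measured in this assay. It differs from compound 2 in one place: 4-methylphenyl in place of 3-chlorophenyl on a nitrogen on an aromatic ring. Among the compounds with values here, nothing among the measured compounds tests this exchange, and the two limits give no direction for it. A small step is therefore expected, a 1.7-fold higher number from compound 2 to compound 4 (0.22 log units; within the scatter), of a size that stays within the usual scatter and leans neither way with any confidence. Compound 4 is estimated at 20000 nM, within a range from 6000 nM to 70000 nM, with a real chance that the assay returns only a limit.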

Compound 4, half-maximal inhibitory concentration: 9420 nM
Beside the measured number, compound 4's estimate is 2.1-fold (0.33 log units) above it, and the stated range covers the measured number.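

Going by these compounds alone, this is the first measured step at this place on the shared core: in this assay, 4-methylphenyl in place of 3-chlorophenyl on a nitrogen on an aromatic ring gives a 1.3-fold lower number from compound 2 to compound 4 (0.11 log units; within the scatter). Compound 2 and compound 4 therefore cannot be told apart in this assay, which shows that chlorine is not required on this ring for a measurable number, at least with the rest of compound 2 held fixed. Nothing shown accounts for why these two groups read alike, and the two limits recorded for the other compounds do not bear on this exchange.

This single exchange replaces the chlorine with a methyl and also moves the substituent to another ring position, so the two alterations cannot be separated, and they could have opposing effects that happen to cancel. A 3-methylphenyl or 4-chlorophenyl group would pull them apart, while an unsubstituted phenyl or a 4-aminophenyl group at the same nitrogen would show whether this place responds to its substituent at all.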